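Cyclopentylamino to cyclohexylmethylamino on the shared core

This account rests on a few compounds, and the source may have more. Where it says the series, first, only, none or still open, it means among the compounds named here.

Three compounds of the series have numbers in an assay on CHO cells for displacement of a labelled ligand from adenosine receptor A1 (Homo sapiens); a lower number here means a stronger inhibitor, a higher number a weaker inhibitor. Compound 3 `CCOC(=O)c1cnc(NC2CCCC2)n2nc(-c3ccco3)nc12` gives 34.4 nM in this assay. Compound 2 `CCOC(=O)c1cnc(NC2CC2)n2nc(-c3ccco3)nc12` gives 60.7 nM, and the step of a 1.8-fold lower number from compound 2 to compound 3 (0.25 log units; within the scatter) lies within the scatter, so the two stand level on the numbers shown. Compound 1 `CNC(=O)c1cnc(NC(=O)NC2CCCCC2)n2nc(-c3ccco3)nc12` differs from compound 3 at several places at once. In this assay, going by the values given here, compound 1 gives 8990 nM, a far higher number, and no single-point step joins it to the others.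

Compound 4 `CCOC(=O)c1cnc(NCC2CCCCC2)n2nc(-c3ccco3)nc12` is the next member to be measured in this assay. The change from compound 3 is cyclohexylmethyl in place of cyclopentyl on a nitrogen on an aromatic ring. Among the compounds with values here, only one measured step bears on it: the change of ring size on the same nitrogen, a 1.8-fold lower number from compound 2 to compound 3 (0.25 log units; within the scatter), which stayed within the scatter. The new group is again a saturated carbon ring on that nitrogen, now with one more ring member and a one-carbon link, and nothing in the three values speaks for a large move in either direction.

The estimate for compound 4 is therefore 50 nM, with a range of 15 nM to 200 nM, a step of a 1.5-fold higher number from compound 3 to compound 4 (0.16 log units; within the scatter) that is expected to stay within the scatter.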

Compound 4, inhibition constant: 432 nM
The estimate for compound 4 lay 8.6-fold (0.94 log units) below the measured number, outside the stated range (above it).
By their numbers in this assay, from the lowest: compounds 3 and 2 (each within the scatter of the next); then compound 4; then compound 1.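

In this assay, cyclohexylmethyl in place of cyclopentyl on the nitrogen gives a 13-fold higher number from compound 3 to compound 4 (1.10 log units; beyond the scatter), and cyclohexylmethyl in place of cyclopropyl gives a 7.1-fold higher number from compound 2 to compound 4 (0.85 log units; beyond the scatter). Going by these compounds alone, the only earlier step at this position, a 1.8-fold lower number from compound 2 to compound 3 (0.25 log units; within the scatter), stayed within the scatter, so the cyclopropyl and cyclopentyl compounds gave no sign that the group on this nitrogen matters, whereas both new steps lie beyond the scatter and show that the number does respond to a change here. Among the three compounds compared at this position, cyclohexylmethyl is the one group that moves the number, and nothing shown bears on why the number rises with this group.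

Cyclohexylmethyl differs from the other two groups in both its six-membered ring and its link to the nitrogen, so the compounds shown leave open which of the two carries the step. Cyclohexyl and cyclopentylmethyl on the same nitrogen would separate these two changes, and an open chain such as butyl would show whether a ring is needed there at all.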